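Fluoro for methyl on the benzyl arm of compound 1

A few compounds are considered here, and "the series" means these few. Any claim that something is new, unique, unknown or untested is made for them only; others in the source may bear on it.

Working notes on a small thiazolidinedione-type series, read in a functional assay on L1210 cells (Mus musculus) for cytotoxicity, read by cell counting, with a stated time of 2 days; on this read-out higher numbers stand for weaker inhibition and lower numbers for stronger inhibition.

Of the compounds shown here, two carry numbers so far. Compound 1 `C=C(Br)C(=O)Nc1ccc(/C=C2\SC(=O)N(Cc3ccc(C)cc3)C2=O)cc1` gives 3400 nM in this assay, the lower of the two values. Compound 2 `Nc1cccc(/C=C2\SC(=O)N(Cc3cccc(F)c3)C2=O)c1` differs from compound 1 in several places. In this assay compound 2 gives 199000 nM, a number that sits far above that of compound 1 and beyond the usual scatter. Among the measured compounds shown here, no single-point step between measured compounds is available, so the pair says only that compound 1 stands at the stronger end of what has been seen.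

The next compound keeps the core of compound 1 and changes one group. Compound 3 `C=C(Br)C(=O)Nc1ccc(/C=C2\SC(=O)N(Cc3ccc(F)cc3)C2=O)cc1` differs from compound 1 as follows: fluoro in place of methyl on an aromatic carbon. A swap of this size on the outer benzyl ring is not expected to move the number much; the step of a 1.0-fold higher number from compound 1 to compound 3 (0.01 log units; within the scatter) is estimated to lie within the scatter, with no clear direction. Compound 3 is therefore expected to give about 3500 nM in this assay, in a range from 1200 nM to 10000 nM.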

Compound 3, half-maximal inhibitory concentration: 2200 nM
For compound 3 the middle estimate is 1.6-fold (0.20 log units) above the measured one; the measured number falls inside the stated range.
By their numbers in this assay, from the lowest: compounds 3 and 1 (each within the scatter of the next); then compound 2.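

Among the compounds shown here, at the benzyl arm of the core, going from 4-methylbenzyl to 4-fluorobenzyl gives a 1.5-fold lower number from compound 1 to compound 3 (0.19 log units; within the scatter) in this assay, and this is the first single-point step the series offers. With the rest of compound 1 held fixed, methyl and fluoro on this aromatic carbon, para to a large group, cannot be told apart on this read-out, so this one-atom exchange leaves the number within the noise of the measurement. No measurement on hand bears on why the two groups read alike, and the result is recorded here only as an observation.

Still open, on these data alone, is whether the same position stays this flat for groups of a different kind, such as an amine, a carboxylic acid or a longer chain in place of the methyl, since a swap between two single heavy atoms samples only a narrow part of what the ring could carry. Also open, as far as these compounds go, is what a single change at the amide end of compound 1 would do with the benzyl arm held constant, for instance a free amine at that end.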